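A few compounds are considered here, and "the series" means these few. Any claim that something is new, unique, unknown or untested is made for them only; others in the source may bear on it.

For the measured compounds named here, compound 2 `COc1ccc2c(c1)c(=O)c(C(=O)Nc1ccc(Oc3ncnc4[nH]cc(-c5ccccc5)c34)c(F)c1)c(C)n2C` gives 99 nM in an assay on isolated protein for inhibition of tyrosine-protein kinase receptor UFO (Homo sapiens), read by FRET and Z'-LYTE, with a stated time of 1.5 h (on this read-out higher numbers stand for weaker inhibition and lower numbers for stronger inhibition), the lowest of the two numbers so far; compound 1 `Cc1c(C(=O)Nc2ccc(Oc3ncnc4[nH]cc(-c5ccccc5)c34)c(F)c2)c(=O)c2cc(Br)ccc2n1C` gives 3120 nM, and the change from compound 1 to compound 2 was a 32-fold lower number from compound 1 to compound 2 (1.50 log units; beyond the scatter). Compound 3 `Cc1c(C(=O)Nc2ccc(Oc3ncnc4[nH]cc(-c5ccccc5)c34)c(F)c2)c(=O)c2cc(OC(F)(F)F)ccc2n1C` carries trifluoromethyl in place of methyl on an oxygen on an aromatic ring. Going by the values given here, no measured step covers this change itself; the only step at this position shows that the group there moves the number strongly. A moderate rise, well short of the bromo case, is therefore expected, a 4.0-fold higher number from compound 2 to compound 3 (0.61 log units; beyond the scatter). Compound 3 is estimated at 400 nM, within 100 nM to 1600 nM.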

Compound 3, half-maximal inhibitory concentration: 74 nM
Estimate against measurement, compound 3: 5.4-fold (0.73 log units) above; measured number outside the range, below it.
By their numbers in this assay, from the lowest: compounds 3 and 2 (each within the scatter of the next); then compound 1.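

Fluorinating the methyl of the methoxy group leaves the number unchanged within the scatter in this assay, with a 1.3-fold lower number from compound 2 to compound 3 (0.13 log units; within the scatter). Trifluoromethoxy in place of bromo gives a 42-fold lower number from compound 1 to compound 3 (1.62 log units; beyond the scatter), so at this position both oxygen-linked groups, in compound 2 and compound 3, stand clear of bromo in compound 1. No evidence here accounts for that separation.

On these data alone, whether the oxygen link itself matters stays open: a free hydroxyl, an amine or a longer chain such as ethoxy at this position would help separate that question from the identity of the group.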